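Pyridin-2-yl for phenyl on the amide-side benzyl

This account rests on a few compounds, and the source may have more. Where it says the series, first, only, none or still open, it means among the compounds named here.

Within the data shown here, compound 2 `Cc1cc(C(=O)NCc2ccccc2)nn1Cc1cc(Cl)ccc1OCc1ccccc1` gives 15 mL.min-1.g-1 in an in vitro ADME assay on microsomes from liver (Rattus norvegicus) for metabolic stability (a higher number here means faster removal of the compound, a lower number slower removal), the higher of the two numbers so far; the nearest is compound 1 `Cc1cc(C(=O)Nc2ccccc2)nn1Cc1cc(Cl)ccc1OCc1ccccc1`, which gives 12 mL.min-1.g-1. The step of a 1.3-fold higher number from compound 1 to compound 2 (0.10 log units; within the scatter) is the only measured one, and it lies on the same amide-type nitrogen as the change now in question. Compound 3 `Cc1cc(C(=O)NCc2ccccn2)nn1Cc1cc(Cl)ccc1OCc1ccccc1` differs from compound 2 by pyridin-2-yl in place of phenyl on a saturated chain carbon bound to an amide-type nitrogen. Among the measured compounds shown here, no measured pair shows a phenyl replaced by a pyridin-2-yl, so this change stands without a direct precedent; the one step in hand, a 1.3-fold higher number from compound 1 to compound 2 (0.10 log units; within the scatter), was within the scatter. The expectation is therefore a step of a 1.3-fold lower number from compound 2 to compound 3 (0.10 log units; within the scatter) of no clear direction and not beyond the scatter, with wide uncertainty. Compound 3 is estimated at 12 mL.min-1.g-1, with a range from 4 mL.min-1.g-1 to 35 mL.min-1.g-1.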

Compound 3, intrinsic clearance in microsomes: 30 mL.min-1.g-1
Compound 3: the middle estimate sits 2.5-fold (0.40 log units) below what was measured, and the stated range covers the measured number.
By their numbers in this assay, from the lowest: compounds 1, 2 and 3 (each within the scatter of the next, the first and the last beyond it).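

In this assay, among these compounds, this is the first look at a ring nitrogen at this position: pyridin-2-yl in place of phenyl on a saturated chain carbon bound to an amide-type nitrogen gives a 2.0-fold higher number from compound 2 to compound 3 (0.30 log units; within the scatter), so this change alone cannot be told apart from repeat variation. Read against the anilide, (pyridin-2-yl)methyl in place of phenyl on the amide-type nitrogen gives a 2.5-fold higher number from compound 1 to compound 3 (0.40 log units; beyond the scatter), a modest step and the first in the series to clear the scatter. No measurement at hand accounts for either step.

On these data alone, whether pyridin-3-yl or pyridin-4-yl on the same saturated chain carbon would read like pyridin-2-yl remains open, as does the outcome of a longer chain on the amide-type nitrogen. Also open, as far as these compounds go, is how an amine or a carboxylic acid on the ring would behave.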